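From benzylamine to sulfonamide on the ring carbon

A few compounds are considered here, and "the series" means these few. Any claim that something is new, unique, unknown or untested is made for them only; others in the source may bear on it.

Three compounds sharing one core have numbers in an assay on CHO cells for displacement of a labelled ligand from 5-hydroxytryptamine receptor 1B (Homo sapiens); a higher number here means a weaker inhibitor, a lower number a stronger inhibitor. Compound 1 `CN(CC1CCN(CCCc2c[nH]c3ccc(-n4cnnc4)cc23)CC1)C(=O)Nc1ccccc1` gives 6.2 nM, compound 2 `c1ccc(CNCC2CCN(CCCc3c[nH]c4ccc(-n5cnnc5)cc34)CC2)cc1` gives 28 nM, and compound 3 `OC[C@H](NC1CCN(CCCc2c[nH]c3ccc(-n4ccnc4)cc23)CC1)c1ccccc1` gives 100 nM. Compound 2 thus stands second highest of the three, above compound 1 and below compound 3. Within the data shown here, the one measured step, a 4.5-fold higher number from compound 1 to compound 2 (0.65 log units; beyond the scatter), raised the number modestly when benzylamino replaced methyl(phenylcarbamoyl)amino. Compound 4 `CN(C1CCN(CCCc2c[nH]c3ccc(-n4cnnc4)cc23)CC1)S(=O)(=O)c1ccccc1` goes the other way: methyl(phenylsulfonyl)amino in place of (benzylamino)methyl on a saturated ring carbon, so a methyl returns to the nitrogen and the phenyl is again held through a linking group. Because that earlier step a 4.5-fold higher number from compound 1 to compound 2 (0.65 log units; beyond the scatter) ran against the benzylamino form, compound 4 is expected to give a lower number, a step of a 2.3-fold lower number from compound 2 to compound 4 (0.37 log units; beyond the scatter), with an estimate of 12 nM ranging from 4 nM to 40 nM.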

Compound 4, half-maximal inhibitory concentration: 10 nM
The estimate for compound 4 lay 1.2-fold (0.08 log units) above the measured number; low and high end bracket the measured number.
By their numbers in this assay, from the lowest: compounds 1 and 4 (each within the scatter of the next); then compound 2; then compound 3.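

The ring carbon three ring bonds from the ring nitrogen also accepts a group with 0 hydrogen-bond donors: in this assay, methyl(phenylsulfonyl)amino in place of (benzylamino)methyl gives a 2.8-fold lower number from compound 2 to compound 4 (0.45 log units; beyond the scatter). A donor on this group is therefore not required for a low number here, at least with this phenyl-bearing group. Nothing available explains the shift. The swap alters the link to the phenyl ring and adds the methyl together, leaving their separate contributions open. An amide carbonyl in place of the sulfonyl, or hydrogen in place of the methyl, would help separate them.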